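The source may hold more compounds than are shown below. What is called first, only, known or untested is meant among the compounds shown, and "the series" means these compounds.

Measured compounds in a functional assay on HL-60 cells (Homo sapiens) for cytotoxicity, read by luminescence and CellTiter-Glo, with a stated time of 3 days; a lower number here means a stronger inhibitor, a higher number a weaker inhibitor:
compound 1 `O=C(Nc1ccc(C(F)(F)F)cc1)c1cc(F)ccc1O` gives 490 nM
compound 2 `O=C(Nc1ccc(C(F)(F)F)cc1)c1ccc(Br)cc1O` gives 360 nM
compound 3 `O=C(Nc1ccc(C(F)(F)F)cc1)c1cc(Br)ccc1O` gives 580 nM

Compound 2 shows the lowest of the three numbers, but its gaps to compound 1 and to compound 3 both lie within the scatter, so no order among them is claimed. Compound 2 and compound 3 have the same atoms joined differently; the difference between the two cores is not broken down here. From compound 3 to compound 1 the change is fluoro in place of bromo on an aromatic carbon, and the step in this assay is a 1.2-fold lower number from compound 3 to compound 1 (0.07 log units; within the scatter).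

Compound 4 `O=C(Nc1ccc(C(F)(F)F)cc1)c1ccc(F)cc1O` is not yet measured. It differs from compound 2 by fluoro in place of bromo on an aromatic carbon. The surroundings are not identical: in the measured pair the carbon is meta to a large group and para to a hydroxy group, whereas here it is meta to a hydroxy group and para to a large group, so this is the same kind of change rather than the same change. Resting on the single measured instance, which stayed within the scatter, the expected step from compound 2 to compound 4 is a 1.2-fold lower number from compound 2 to compound 4 (0.08 log units; within the scatter). Compound 4 is estimated at 300 nM, between 150 nM and 600 nM.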

Compound 4, half-maximal inhibitory concentration: 680 nM
Beside the measured number, compound 4's estimate is 2.3-fold (0.36 log units) below it; measured number above the stated range.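

In this assay, fluoro in place of bromo on the core of compound 2 gives a 1.9-fold higher number from compound 2 to compound 4 (0.28 log units; within the scatter). Set beside the earlier instance of the same change, the two steps do not differ by more than two such measurements would be expected to: the same change on two cores in this assay, a 1.2-fold lower number (0.07 log units; within the scatter) from compound 3 to compound 1 and a 1.9-fold higher number (0.28 log units; within the scatter) from compound 2 to compound 4, 2.2-fold (0.35 log units) apart, within the scatter of two such steps. This means that, on these two cores, the change can be carried over only in a narrow sense: neither step can be told apart from no effect, no direction can be read from either, and nothing shows whether the two placements of the halogen respond alike or differently.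

The compounds shown leave open whether a step beyond the scatter appears at these places with a group other than bromo or fluoro, such as an amine or a methoxy group. As far as these compounds go, all four compounds also carry the hydroxy group and the trifluoromethyl group, so the effect of replacing these, for example with a carboxylic acid or a nitrile, remains open.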